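Swapping Trifluoromethoxy for Methyl in Compound 2

A few compounds are considered here, and "the series" means these few. Any claim that something is new, unique, unknown or untested is made for them only; others in the source may bear on it.

Of the compounds shown here, three have numbers so far in a functional assay on HCT-116 cells (Homo sapiens) for antiproliferative activity, read by MTT assay, with a stated time of 72 h (a higher number here means a weaker inhibitor, a lower number a stronger inhibitor), and all lie close together. Compound 2 (`O=S1(=O)C=Cc2cccc(Nc3ccc(OC(F)(F)F)cc3)c21`) gives 2380 nM and so shares the upper end of the range with compound 1 (`O=S1(=O)C=Cc2ccc(Nc3ccc(C(F)(F)F)cc3)cc21`), which gives 1340 nM. The two sit within the usual scatter of repeated measurements. Compound 3 (`COc1cc(Nc2cccc3c2S(=O)(=O)C=C3)cc(OC)c1OC`) gives 1150 nM, a number lower than that of compound 2 by a gap just beyond the scatter. Compound 2 is therefore a somewhat weaker inhibitor than compound 3.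

Compound 4 (`Cc1ccc(Nc2cccc3c2S(=O)(=O)C=C3)cc1`) has not yet been measured. It carries methyl in place of trifluoromethoxy on an aromatic carbon, para to a large group (methyl in place of trifluoromethoxy on an aromatic carbon). Within the data shown here, no measured pair differs in only one place, so there is no direct precedent for this swap. The expectation rests on how narrow the range is, from compound 3 at 1150 nM to compound 2 at 2380 nM. In this assay a small move toward a lower number is expected, probably no larger than the scatter. The estimated step is a 1.4-fold lower number from compound 2 to compound 4 (0.15 log units; within the scatter). For compound 4 the estimated value is 1700 nM, with an expected range from 700 nM to 4200 nM.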

Compound 4, half-maximal inhibitory concentration: 4000 nM
Estimate against measurement, compound 4: 2.4-fold (0.37 log units) below; low and high end bracket the measured number.
By their numbers in this assay, from the lowest: compounds 3, 1, 2 and 4 (each within the scatter of the next, the first and the last beyond it).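

In this assay, among these compounds, the swap gives a 1.7-fold higher number from compound 2 to compound 4 (0.23 log units; within the scatter), the first step here between two compounds that differ in one place only. The step lies within the usual scatter of repeated measurements, so this assay does not separate the two compounds, even though trifluoromethoxy, with 5 heavy atoms and 1 hydrogen-bond acceptor, gives way to methyl, with 1 heavy atom and 0 hydrogen-bond acceptors, on an aromatic carbon para to a large group. No independent measurement bears on this result, and the data offer no explanation of it.

Still open, from the compounds shown here alone, is whether a different group in this place, such as an amine, a carboxylic acid or a longer chain like propyl, would produce a step beyond the scatter. This single pair also sets no rule for the same swap on other compounds, and a second pair with this change would be needed to show whether the result holds more widely.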